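Methoxymethyl to methyl: from compound 3 to compound 4

The source may report more compounds than this note shows. Statements on the series, on what has been measured and on what is new or still open speak of the compounds shown alone.

For the measured compounds named here, in a physicochemical assay for lipophilicity, read by HPLC, at pH 7.5 (a lower number here means a more polar compound, a higher number a more lipophilic compound), compound 3 (`CC[C@@H](Nc1c(C#N)c(-c2ccc(-c3ccccc3COC)cc2)nc2cnccc12)C(N)=O`) gives 2.6 as the lowest of the three numbers so far. On the same core, compound 1 (`CC[C@@H](Nc1c(C#N)c(-c2ccc(-c3cccc(C)c3F)cc2)nc2cnccc12)C(N)=O`) gives 3 and compound 2 (`CC[C@@H](Nc1c(C#N)c(-c2ccc(-c3cccc(Cl)c3F)cc2)nc2cnccc12)C(N)=O`) gives 3.1 in this series.

Compound 4 (`CC[C@@H](Nc1c(C#N)c(-c2ccc(-c3ccccc3C)cc2)nc2cnccc12)C(N)=O`) is the next to be read. It differs from compound 3 by one change (hydrogen in place of methoxy on a saturated chain carbon bound to an aromatic carbon), which is hydrogen in place of methoxy on a saturated chain carbon bound to an aromatic carbon, so that 2-(methoxymethyl)phenyl becomes 2-methylphenyl.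

Going by the values given here, no measured step makes this exact change. The nearest evidence is the pair of steps that end on the methoxymethyl group, a number 0.40 log units lower from compound 1 to compound 3 (beyond the scatter) and also a number 0.50 log units lower from compound 2 to compound 3 (beyond the scatter) in the same direction. The remaining step is a number 0.10 log units higher from compound 1 to compound 2 (within the scatter) and gives no separate guide to size.

Read in reverse, the first two steps suggest a modest rise in this assay on leaving the methoxymethyl group. The expected step is a number 0.40 log units higher from compound 3 to compound 4 (beyond the scatter) on this reasoning. The estimate for compound 4 is 3 with an expected range from 2.7 to 3.3 in this assay series.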

Compound 4, distribution coefficient: 3
The estimate for compound 4 equals the measured number at the digits printed; the measured number falls inside the stated range.
By their numbers in this assay, from the lowest: compound 3; then compounds 1, 4 and 2 (each within the scatter of the next).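

In this assay, hydrogen in place of methoxy on a saturated chain carbon bound to an aromatic carbon gives a number 0.40 log units higher from compound 3 to compound 4 (beyond the scatter). For the compounds shown here, this is the first step that isolates the methoxy group, whereas the earlier steps to compound 3 exchanged the whole aromatic substituent, so the low reading of compound 3 now tracks with the methoxy group itself. The 2-methylphenyl group also reads alongside the two substituents carrying fluoro, with a number 0.10 log units lower from compound 2 to compound 4 (within the scatter) and no change at the digits printed from compound 1 to compound 4 (within the scatter), which leaves 2-(methoxymethyl)phenyl as the only substituent shown that stands apart, and no measurement bearing on the origin of this step is available.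

Still open, going by these compounds, is how a hydroxyl, an amine, a carboxylic acid or a longer chain such as ethoxymethyl on this carbon would read in this assay. Also open, on these data alone, is whether methoxy to hydrogen gives a step of similar size on a ring that also carries fluoro or chloro, as the direct evidence for this change rests on a single pair.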